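The compounds below may be only part of what the source reports. "The series", "measured", "known", "first", "only" and "open" are said of these compounds alone.

In an assay on isolated protein for displacement of a labelled ligand from metabotropic glutamate receptor 5 (Homo sapiens), with a stated time of 60 min, tested at 1 uM (a lower number here means less inhibition, a higher number more inhibition at the concentration tested (going by the name of the read-out)), compound 1 `CC1CCN(c2c(S(=O)(=O)c3ccc(Cl)cc3)cnc3ccc(F)cc23)CC1` gives 80%, and compound 2 `CC1CCN(c2c(S(=O)(=O)c3cccc(Cl)c3)cnc3ccc(F)cc23)CC1` gives 92%. For the measured compounds named here, the one step between them, a number 12 percentage points higher from compound 1 to compound 2 (beyond the scatter), comes from a 3-chlorophenyl in place of a 4-chlorophenyl on the sulfonyl sulfur. Compound 3 `Cc1ccc2ncc(S(=O)(=O)c3ccc(C)c(F)c3)c(N3CCC(C)CC3)c2c1` gives 91% in this assay, the second highest of the three numbers: compound 2 sits within the scatter of it, while compound 1 lies lower by an amount beyond the scatter.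

Compound 4 `Cc1ccc(S(=O)(=O)c2cnc3ccc(F)cc3c2N2CCC(C)CC2)cc1F` differs from compound 3 in a single place: fluoro in place of methyl on an aromatic carbon. Going by the values given here, no measured step bears on this change; the only step known, a 3-chlorophenyl in place of a 4-chlorophenyl on a sulfonyl sulfur, concerns another part of the molecule and was modest. Compounds 1 and 2, which carry a fluoro on their core, both give high readings, so the expectation is a step of a number 5 percentage points lower from compound 3 to compound 4 (within the scatter), not beyond the scatter. Compound 4 is therefore estimated at 86%, within a range from 72% to 96%.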

Compound 4, a percentage reported as inhibition, at one concentration (the size of the read-out at that concentration, not a potency): 86%
Beside the measured number, compound 4's estimate shows no gap at the digits printed, and the stated range covers the measured number.
By their numbers in this assay, from the lowest: compounds 1, 4, 3 and 2 (each within the scatter of the next, the first and the last beyond it).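

In this assay, for the compounds shown here, the first change on the core itself, fluoro in place of methyl on an aromatic carbon, gives a number 5 percentage points lower from compound 3 to compound 4 (within the scatter) and so shows that the reading at this position stays high with either group. With fluoro held on the core, the 3-fluoro-4-methylphenyl on the sulfonyl sulfur gives a number 6 percentage points lower from compound 2 to compound 4 (within the scatter) and a number 6 percentage points higher from compound 1 to compound 4 (within the scatter) and thus cannot be told apart from either chlorophenyl, although those two differ from each other beyond the scatter. Nothing at hand explains these readings.

Only methyl and fluoro are shown at this position, so what a methoxy, a nitrile or an amine would give there remains open. These readings at a single concentration also leave the potencies of the compounds open.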